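The source may hold more compounds than are shown below. What is called first, only, known or untested is meant among the compounds shown, and "the series" means these compounds.

Measured in an assay on membranes from HeLa cells for displacement of a labelled ligand from adenosine receptor A3 (Homo sapiens), read by scintillation counting, with a stated time of 180 min, tested at 1 uM; a higher number here means more inhibition at the concentration tested (going by the name of the read-out), a lower number less inhibition:
compound 1 `CC1=C(C(=O)OCC(C)C)C(c2ccoc2)NC(=O)N1`: 16%
compound 2 `CC1=C(C(=O)OCC(C)C)C(c2cccs2)NC(=O)N1`: 11%
compound 3 `CC1=C(C(=O)OCC(C)C)C(c2cccs2)NC(=O)N1C`: 5%

Compound 2 sits second of the three numbers; its values against compound 1 and compound 3 both fall within the scatter, so no order among them is claimed. Compound 4 `CC1=C(C(=O)CC(C)C)C(c2cccs2)NC(=O)N1` has not been tested. The change is isobutyl in place of isobutoxy on a carbonyl carbon. Neither measured step touches the carbonyl carbon: the step of a number 5 percentage points lower from compound 1 to compound 2 (within the scatter) and the step of a number 6 percentage points lower from compound 2 to compound 3 (within the scatter) both stayed within the scatter and concern other positions, so they bear only indirectly. Among the measured compounds shown here, no step of comparable kind exists. The expected step of a number 1 percentage points lower from compound 2 to compound 4 (within the scatter) is therefore none beyond the scatter. Compound 4 is estimated at 10%, range 0% to 25%.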

Compound 4, a percentage reported as inhibition, at one concentration (the size of the read-out at that concentration, not a potency): 18%
For compound 4 the middle estimate is 8 percentage points below the measured one; the range from low to high includes it.
By their numbers in this assay, from the lowest: compounds 3, 2, 1 and 4 (each within the scatter of the next, the first and the last beyond it).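

At this carbonyl carbon, the first change read in this assay is isobutyl in place of isobutoxy, a number 7 percentage points higher from compound 2 to compound 4 (within the scatter), so removing the oxygen and its counted hydrogen-bond acceptor from this substituent gives no shift beyond the scatter. An ester link is therefore not shown to be required for the read-out at this single concentration. No available evidence bears on the reason for this result.

On these data alone, whether an amide, a carboxylic acid or a longer chain on this carbonyl carbon would move the number beyond the scatter remains open. Also open, as far as these compounds go, is whether the same exchange would read alike with the furan-3-yl of compound 1.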